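The source may report more compounds than this note shows. Statements on the series, on what has been measured and on what is new or still open speak of the compounds shown alone.

Working notes on the series

Compound 1 `CC(C)N(Cc1cccc(OCCCCCC(=O)O)c1)C(=O)c1ccc(-c2cccc(N(C)C)c2)cc1` carries a dimethylamino group on the outer aromatic ring. In an ADME assay on HepG2 cells (Homo sapiens) for cytotoxicity, read by CellTiter-Glo and resazurin assay, with a stated time of 72 h (on this read-out lower numbers stand for an effect already at smaller amounts and higher numbers for an effect only at larger amounts of compound), compound 1 gives > 26000 nM, which is a limit of the assay and not a number. Compound 2 `CC(C)Oc1cccc(-c2ccc(C(=O)N(Cc3cccc(OCCCCCC(=O)O)c3)C(C)C)cc2)c1` replaces that group with isopropoxy. In this assay compound 2 gives > 26000 nM, again a limit rather than a number. Among the measured compounds shown here, the only measured step, a step that the two limits leave unreadable from compound 1 to compound 2, is therefore unreadable; both values sit at the same ceiling, as summarised by the limit of > 26000 nM in this assay, at which 2 of the 2 values shown sit, so compound 2 stands at the limit, with no number placing it relative to compound 1.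

Compound 3 `CCOc1cccc(-c2ccc(C(=O)N(Cc3cccc(OCCCCCC(=O)O)c3)C(C)C)cc2)c1` is the next member: the change is hydrogen in place of methyl on a saturated chain carbon bound to an oxygen on an aromatic ring and a saturated chain carbon, which cut one bond further out reads isopropoxy to ethoxy, or 3-isopropoxyphenyl to 3-ethoxyphenyl. For the measured compounds named here, no measured step bears on this change, since a step that the two limits leave unreadable from compound 1 to compound 2 is unreadable and touches a different group. A step that the limit leaves unreadable from compound 2 to compound 3 is therefore expected, that is none beyond the scatter, with the result most likely again a limit. Compound 3 is estimated at 40000 nM in this assay, within a range from 15000 nM to 150000 nM, pending measurement.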

Compound 3, half-maximal effective concentration: > 20800 nM
Compound 3: no number, only a limit (the forecaster's own chance of this, stated with the estimate: 85%); the middle value is on the limit's open side.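

In this assay compound 3 gives > 20800 nM as a limit of the assay and not a number, so the steps joining compound 1, compound 2 and compound 3 cannot be read. The compounds shown leave open whether dimethylamino, isopropoxy and ethoxy differ in this assay at all, since none of the three compounds has a numerical value.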